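Moving from Trifluoromethyl to Hydroxy on the Aniline Ring

This account rests on a few compounds, and the source may have more. Where it says the series, first, only, none or still open, it means among the compounds named here.

Compound 3, `O=C(/C=C\Nc1ccc(C(F)(F)F)cc1)c1cn(-c2ccccc2)nc1-c1ccc(Cl)cc1`, was tested in a functional assay on A549 cells (Homo sapiens) for antiproliferative activity, read by MTT assay, with a stated time of 48 h; on this read-out lower numbers stand for stronger inhibition and higher numbers for weaker inhibition. In this assay compound 3 reaches only the limit of > 50000 nM, so no number is known for it. Two close relatives carry other groups on the same aromatic carbon. Compound 2, `O=C(/C=C\Nc1ccc(Cl)cc1)c1cn(-c2ccccc2)nc1-c1ccc(Cl)cc1`, gives 3670 nM in this assay. Compound 1, `O=C(/C=C\Nc1ccc(F)cc1)c1cn(-c2ccccc2)nc1-c1ccc(Cl)cc1`, likewise stops at the limit of > 50000 nM. The step of an at least 13-fold lower number from compound 1 to compound 2 (1.13 log units; beyond the scatter) and the step of an at least 13-fold higher number from compound 2 to compound 3 (1.13 log units; beyond the scatter) show that chloro stands apart from both neighbours, while the step that the two limits leave unreadable from compound 1 to compound 3 cannot be read because of the limit of > 50000 nM in this assay, at which 2 of the 3 values shown sit. Compound 4, `O=C(/C=C\Nc1ccc(O)cc1)c1cn(-c2ccccc2)nc1-c1ccc(Cl)cc1`, differs from compound 3 by hydroxy in place of trifluoromethyl on an aromatic carbon. Within the data shown here, no measured compound carries a hydroxy here, so the only guide is that two of three groups at this position gave no readable number and one gave a weak but measurable one. Compound 4 is therefore expected near 20000 nM, with a range from 3000 nM to 80000 nM. This estimate implies the step of an at least 2.5-fold lower number from compound 3 to compound 4 (0.39 log units; beyond the scatter), which is expected to remain uncertain in direction.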

Compound 4, half-maximal inhibitory concentration: 1910 nM
Compound 4: the middle estimate sits 10-fold (1.02 log units) above what was measured; measured number below the stated range.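

In this assay, hydroxy is the second group at this position to give a measured number, with large steps of an at least 26-fold lower number from compound 3 to compound 4 (1.41 log units; beyond the scatter) and an at least 26-fold lower number from compound 1 to compound 4 (1.41 log units; beyond the scatter). On these data alone, both steps start from a limit and not from a number, so their true size stays unknown: the limit of > 50000 nM in this assay, at which 2 of the 4 values shown sit. The step of a 1.9-fold lower number from compound 2 to compound 4 (0.28 log units; within the scatter) separates hydroxy from chloro by no more than the usual scatter, so a measurable value at this position is not tied to chloro alone.

These four groups on one aromatic carbon do not show what sets chloro and hydroxy apart from fluoro and trifluoromethyl. As far as these compounds go, it also stays open whether an amine or a methoxy group at the same place would give a measured number or stop at the limit.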